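A few compounds are considered here, and "the series" means these few. Any claim that something is new, unique, unknown or untested is made for them only; others in the source may bear on it.

Working notes, cytotoxicity series.

The three measured compounds were run in an ADME assay on Huh-7 cells (Homo sapiens) for cytotoxicity; a higher number here means that more compound is tolerated, a lower number that less compound is tolerated. Compound 1 `CN1CCN(CCCNCc2cn(-c3ccc([N+](=O)[O-])cc3)nc2-c2ccc(OC(F)(F)F)cc2)CC1` gives 1600 nM in this assay. Compound 2 `Cc1ccccc1-c1nn(Cc2ccc(F)cc2)cc1CNCCN1CCN(C)CC1` reaches only the limit of this assay, reported as > 20000 nM. Compound 3 `Cc1c(CNCCN2CCN(C)CC2)c(-c2ccccc2)nn1-c1ccc(F)cc1` likewise sits at a limit, reported as > 20000 nM. Among the compounds with values here, compound 2 therefore stands at the limit of > 20000 nM in this assay, at which 2 of the 3 values shown sit, with no number of its own, and only compound 1 supplies a measured concentration, so no step between measured compounds that differ in one place can be drawn.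

Compound 4 `Cc1ccc(-n2cc(CNCCN3CCN(C)CC3)c(-c3ccccc3C)n2)c(C)c1` has not yet been measured in this assay. It differs from compound 2 by 2,4-dimethylphenyl in place of 4-fluorobenzyl on an aromatic nitrogen; in words, 2,4-dimethylphenyl in place of 4-fluorobenzyl on an aromatic nitrogen. With compound 2 and compound 3 both at the limit, no shift beyond the usual scatter is expected, and the step of a number no higher from compound 2 to compound 4 (the limit leaves the size open) is estimated to be small. Compound 4 is expected to tolerate about 20000 nM, within 8000 nM to 40000 nM, most probably again reported only as a limit.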

Compound 4, half-maximal cytotoxic concentration: > 20000 nM
Compound 4 gave a limit, no number; the forecaster's own chance of this, stated with the estimate: 65%; the middle value lies on the limit itself.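

No step can be read between compound 2 and compound 4, since each gives only a limit and no number: the limit of > 20000 nM in this assay, at which 3 of the 4 values shown sit.

The compounds shown leave open whether 2,4-dimethylphenyl and 4-fluorobenzyl on an aromatic nitrogen differ at all in how much compound is tolerated.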